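Rearranging a dialkylamino group on a shared core

This account rests on a few compounds, and the source may have more. Where it says the series, first, only, none or still open, it means among the compounds named here.

Compound 1 `CCCN(CCC)c1nc(C)nc2c(-c3c(C)cc(N(C)C)nc3C)c(C)nn12`: 14.9 nM
Compound 2 `CCN(CC)c1nc(C)nc2c(-c3cnc(OC)cc3C)c(C)nn12`: 14.5 nM
Compound 3 `CCN(CC)c1nc(C)nc2c(-c3ccc(OC)nc3C)c(C)nn12`: 12 nM

Of the compounds shown here, three have been measured in an assay on cell membranes for displacement of a labelled ligand from corticotropin-releasing factor receptor 1 (Rattus norvegicus); a lower number here means a stronger inhibitor, a higher number a weaker inhibitor. Compound 1 gives 14.9 nM, which is the highest of the three numbers, yet its gap to compound 2 at 14.5 nM and to compound 3 at 12 nM both lie within the scatter of repeated measurements, so the three cannot be ordered on these numbers. Among the measured compounds shown here, no pair among them differs in only one place, so no single-point step has been measured.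

Compound 4 `CCCCN(CC)c1nc(C)nc2c(-c3c(C)cc(N(C)C)nc3C)c(C)nn12` has not yet been measured. It differs from compound 1 by butyl(ethyl)amino in place of dipropylamino on an aromatic carbon; the two share the same atoms, joined differently. For the measured compounds named here, with no measured step to lean on, and the two substituents matched in size and in counted donors and acceptors, the step is expected to stay within the scatter, in no particular direction. Compound 4 is therefore estimated at 15 nM, with a range from 5 nM to 45 nM. This corresponds to an expected step of a 1.0-fold higher number from compound 1 to compound 4 (0.00 log units; within the scatter).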

Compound 4, half-maximal inhibitory concentration: 32.8 nM
Compound 4: the middle estimate sits 2.2-fold (0.34 log units) below what was measured, and the stated range covers the measured number.
By their numbers in this assay, from the lowest: compounds 3, 2 and 1 (each within the scatter of the next); then compound 4.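

Rearranging the same atoms from dipropylamino to butyl(ethyl)amino, on the aromatic carbon between two ring nitrogen atoms, gives a 2.2-fold higher number from compound 1 to compound 4 (0.34 log units; beyond the scatter) in this assay and is the first measured single-place step in this set. The result shows that this position responds to how the chains on the amine are arranged, even when the entering and leaving groups match in heavy atoms, donors and acceptors. Nothing available explains the step.

The compounds shown leave open whether the step follows from the butyl chain itself or from having two unequal chains, a question that dibutylamino or ethyl(propyl)amino on the core of compound 1 could address. They also leave open whether the same change would give a step of similar size on the other cores shown here.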